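The source may report more compounds than this note shows. Statements on the series, on what has been measured and on what is new or still open speak of the compounds shown alone.

The measured compounds and their values in an assay on isolated protein for inhibition of Nicotinamide phosphoribosyltransferase (Homo sapiens), read by colorimetric assay, with stated times of 60 min, 30 min and 5 min; on this read-out lower numbers stand for stronger inhibition and higher numbers for weaker inhibition:

Compound 1, `C#Cc1cccc(Nc2ncnc3cc(OC)c(OCCCCCCN/C(=N\C#N)Nc4cccnc4)cc23)c1`: 133 nM
Compound 2, `C#Cc1cccc(Nc2ncnc3cc(OC)c(OCCCCCCCN/C(=N\C#N)Nc4cccnc4)cc23)c1`: 152 nM
Compound 3, `C#Cc1cccc(Nc2ncnc3cc(OC)c(OCCCCCN/C(=N\C#N)Nc4ccncc4)cc23)c1`: 41.2 nM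

Compound 2 gives the highest of the three numbers in this assay. Its nearest neighbour is compound 1, whose number sits within the scatter of that of compound 2, so the two cannot be told apart. Compound 3 gives a number beyond the scatter lower than that of compound 2, but compound 3 differs from compound 2 in more than one place, in the length of the linking chain as well as in the pyridine group on the amine nitrogen, so that gap cannot be pinned on one change.

Compound 4 is `C#Cc1cccc(Nc2ncnc3cc(OC)c(OCCCCCCCN/C(=N\C#N)Nc4ccncc4)cc23)c1` and has not yet been measured. It differs from compound 2 in one place: pyridin-4-yl in place of pyridin-3-yl on an amine nitrogen. Among the compounds with values here, no measured pair isolates this change on its own. Still, a modest lowering of the number is expected for the step of a 2.0-fold lower number from compound 2 to compound 4 (0.31 log units; beyond the scatter), because compound 3 with its pyridin-4-yl group gives 41.2 nM. Compound 4 is therefore estimated to give 75 nM, in a range from 30 nM to 190 nM.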

Compound 4, half-maximal inhibitory concentration: 154 nM
Compound 4: the middle estimate sits 2.1-fold (0.31 log units) below what was measured; the range from low to high includes it.
By their numbers in this assay, from the lowest: compound 3; then compounds 1, 2 and 4 (each within the scatter of the next).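

In this assay the swap of pyridin-3-yl for pyridin-4-yl on this amine nitrogen gives a 1.0-fold higher number from compound 2 to compound 4 (0.01 log units; within the scatter) and leaves the two groups indistinguishable with this linking chain. Compound 3 carries the same pyridin-4-yl group on a shorter linking chain and gives 41.2 nM while compound 4 gives 154 nM on the longer one, so pyridin-4-yl alone does not bring the low number of compound 3. No measurement at hand offers an explanation for this result.

Still open, going by these compounds, is whether pyridin-3-yl on the shorter chain of compound 3 would give a number close to that of compound 3. Also open, on these data alone, is how a pyridin-2-yl group or a plain phenyl ring would read on this amine nitrogen.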